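Methoxy in place of methyl on the shared core

The source may hold more compounds than are shown below. What is called first, only, known or untested is meant among the compounds shown, and "the series" means these compounds.

Of the compounds shown here, three carry numbers so far: compound 1 (`COc1ccc2c(c1)nc(/C=C/C(=O)/C=C/c1ccc(O)c(OC)c1)n2C`), compound 2 (`COc1ccc(/C=C/C(=O)/C=C/c2nc3ccccc3n2C)cc1O`) and compound 3 (`COc1ccc(/C=C/C(=O)/C=C/c2nc3cc(C)ccc3n2C)cc1O`). In a functional assay on NCI-H460 cells (Homo sapiens) for cytotoxicity, read by MTT assay, with a stated time of 48 h (on this read-out higher numbers stand for weaker inhibition and lower numbers for stronger inhibition), compound 2 gives 6900 nM, compound 3 gives 7700 nM and compound 1 gives 12700 nM. Compound 3 does not stand apart, since its value lies within the scatter of those of both compound 2 and compound 1.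

The next case is compound 4 (`COc1ccc2c(c1)nc(/C=C/C(=O)/C=C/c1ccc(OC)c(O)c1)n2C`), which has methoxy in place of methyl on an aromatic carbon of compound 3: methoxy in place of methyl on an aromatic carbon. Among the measured compounds shown here, the only measured step at this carbon is a 1.1-fold higher number from compound 2 to compound 3 (0.05 log units; within the scatter), methyl in place of hydrogen, and it stays within the scatter. For the measured compounds named here, that step says little about methoxy, and no measured pair isolates methyl against methoxy. Compound 1 also bears methoxy at this carbon and gives 12700 nM, but it differs from compound 4 elsewhere, so it offers only loose support for a small upward drift in this assay. No shift beyond the scatter is expected. The expected step is a 1.2-fold higher number from compound 3 to compound 4 (0.07 log units; within the scatter). For compound 4 the estimated value is 9000 nM, with an expected range of 4500 nM to 17000 nM.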

Compound 4, half-maximal inhibitory concentration: 11700 nM
Beside the measured number, compound 4's estimate is 1.3-fold (0.11 log units) below it; measured number inside the range.
By their numbers in this assay, from the lowest: compounds 2, 3, 4 and 1 (each within the scatter of the next).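

In this assay, this aromatic carbon of the shared core now carries three groups, and neither step to methoxy leaves the scatter: a 1.5-fold higher number from compound 3 to compound 4 (0.18 log units; within the scatter) for methoxy in place of methyl, and a 1.7-fold higher number from compound 2 to compound 4 (0.23 log units; within the scatter) for methoxy in place of hydrogen. Thus hydrogen, methyl and methoxy are not separated at this carbon, a reading that the earlier hydrogen-to-methyl step alone could not extend to methoxy. With methoxy held on the core, a second comparison also stays within the scatter: a 1.1-fold lower number from compound 1 to compound 4 (0.04 log units; within the scatter) for 3-hydroxy-4-methoxyphenyl in place of 4-hydroxy-3-methoxyphenyl, so these two arrangements of the phenyl substituents are not told apart in this assay. No accompanying data bear on why these steps stay so small.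

On these data alone, whether a group of another kind on this aromatic carbon, such as an amine or a carboxylic acid, would give a step beyond the scatter remains open. Also open, as far as these compounds go, is whether replacing the hydroxy on the phenyl ring with an amine would move the number in this assay any further than the exchange of the two phenyl arrangements does.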